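The compounds below may be only part of what the source reports. "The series", "measured", "known", "first", "only" and "open" are said of these compounds alone.

Measured so far:
compound 1 `CCS(=O)(=O)Nc1cccc2c1CCCC2c1c[nH]cn1` — 1320 nM
compound 2 `CCS(=O)(=O)Nc1cccc2c1CCCC2(O)c1c[nH]cn1` — < 10000 nM (a limit of the assay)
compound 3 `CCS(=O)(=O)Nc1cccc2c1CCCC2c1c[nH]c(C)n1` — < 10000 nM (a limit of the assay)

Within the data shown here, in an assay on isolated protein (Cricetulus griseus) for binding affinity to Alpha-1B adrenergic receptor (Mesocricetus auratus), read by radioligand binding (on this read-out lower numbers stand for stronger inhibition and higher numbers for weaker inhibition), compound 1 gives 1320 nM, the only number in the set. Compound 2 gives < 10000 nM, which is a limit and not a number. Compound 3 gives < 10000 nM, again a limit only. The step that the limit leaves unreadable from compound 1 to compound 2 cannot be sized, and the same holds for a step that the limit leaves unreadable from compound 1 to compound 3, because the limit of < 10000 nM in this assay, at which 2 of the 3 values shown sit, hides both end points.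

Compound 4 `CN(c1cccc2c1CCCC2c1c[nH]cn1)S(C)(=O)=O` differs from compound 1 by methyl(methylsulfonyl)amino in place of (ethylsulfonyl)amino on an aromatic carbon. Neither measured step touches the sulfonamide side of the core of compound 1; both concern the saturated ring carbon or the imidazole carbon, and both are unreadable anyway. There is therefore no measured guide for this change in this assay. The working expectation for compound 4 is a step to weaker binding of moderate size, a 3.0-fold higher number from compound 1 to compound 4 (0.48 log units; beyond the scatter), with wide uncertainty in both directions. On that basis compound 4 is estimated at 4000 nM in this assay, within a range from 1000 nM to 20000 nM, and there is a real chance that the assay returns only a limit, as it did for compound 2 and compound 3.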

Compound 4, inhibition constant: < 10000 nM
Compound 4 was reported as a limit; the forecaster's own chance of this, stated with the estimate: 35%; the middle value does not contradict the limit.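

Compound 4 gives < 10000 nM in this assay, a limit of the assay and not a number. Among these compounds, no step from compound 1 to compound 4 can be read: the limit of < 10000 nM in this assay, at which 3 of the 4 values shown sit. Going by these compounds, whether methyl(methylsulfonyl)amino in place of (ethylsulfonyl)amino on an aromatic carbon changes binding, in which direction and by how much, stays open.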